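Replacing a Methylphenyl Group on a Piperidine Sulfonamide

The source may report more compounds than this note shows. Statements on the series, on what has been measured and on what is new or still open speak of the compounds shown alone.

Compound 1 `COc1ccccc1-c1cccc(S(=O)(=O)N2CCC(N3CCC(C)CC3)CC2)c1`: in an ADME assay on HCT-116 cells (Homo sapiens) for cytotoxicity, read by CellTiter-Glo, with a stated time of 72 h (on this read-out higher numbers stand for weaker inhibition and lower numbers for stronger inhibition), compound 1 gives > 5000 nM, a limit of the assay.
Compound 2 `Cc1ccc(C2CCN(S(=O)(=O)c3c(C)cc(C)cc3C)CC2)cc1`: in this assay compound 2 gives > 5000 nM, a limit of the assay.
Compound 3 `CCc1ccc(S(=O)(=O)N2CCC(N3CCC(C)CC3)CC2)cc1`: in this assay compound 3 gives > 5000 nM, a limit of the assay.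

Compound 2 stands at the same point as the other two: the limit of > 5000 nM in this assay, at which 3 of the 3 values shown sit. No number separates it from compound 1 or compound 3. Compound 4 `Cc1cc(C)c(S(=O)(=O)N2CCC(C3OCC(C)CO3)CC2)c(C)c1` differs from compound 2 in one place: a group of 7 heavy atoms (5 carbon, 2 oxygen; one six-membered non-aromatic ring with 2 hetero atoms) in place of a group of 7 heavy atoms (7 carbon; one six-membered aromatic ring of carbon only), on a saturated ring carbon. Among the compounds with values here, all values so far are limits, and no measured step between two compounds is available to calibrate this change. In this assay the expected step is a step that the limit leaves unreadable from compound 2 to compound 4, none beyond the scatter. Compound 4 is therefore expected at 10000 nM in this assay, within a range from 5000 nM to 30000 nM, and most likely reported again only as a limit.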

Compound 4, half-maximal inhibitory concentration: > 5000 nM
Compound 4 gave a limit, no number; the forecaster's own chance of this, stated with the estimate: 85%; the middle value does not contradict the limit.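

Within the data shown here, compound 2 and compound 4 both give only a limit in this assay, so no step between them can be read: the limit of > 5000 nM in this assay, at which 4 of the 4 values shown sit. On these data alone, whether replacing 4-methylphenyl with the new ring changes inhibition at all stays open.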